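The source may report more compounds than this note shows. Statements on the series, on what has been measured and on what is new or still open speak of the compounds shown alone.

Compound 1 (`CCC(CC)CNc1c(C(N)=O)cnc2ccc(C#N)cc12`): 3.5
Compound 2 (`C[C@@H](Nc1c(C(N)=O)cnc2ccc(-c3cccnc3)cc12)c1ccc(Cl)cc1`): > 4.3 (a limit, not a number)
Compound 3 (`NC(=O)c1cnc2ccc(-c3cccnc3)cc2c1NC1CCCC1`): 3.6

In a physicochemical assay for lipophilicity, using the shake flask method, measured as octanol-water partition, at pH 7.4 (on this read-out lower numbers stand for lower lipophilicity and higher numbers for higher lipophilicity), compound 3 gives 3.6, within the usual scatter of compound 1 at 3.5. Compound 2 reports only a limit, > 4.3. Compound 4 (`NC(=O)c1cnc2ccc(-c3cccnc3)cc2c1NC1CCCCC1`) carries cyclohexyl in place of cyclopentyl on a nitrogen on an aromatic ring. One measured step changes the group at this place: a number at least 0.70 log units lower from compound 2 to compound 3 (beyond the scatter). Within the data shown here, that exchange involved a very different group, and it shows only that the number can move with the group here. A small upward step is expected for this closer exchange, a number 0.30 log units higher from compound 3 to compound 4 (within the scatter). Compound 4 is estimated at 3.9, with an expected range of 3.5 to 4.3.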

Compound 4, distribution coefficient: 3.8
For compound 4 the middle estimate is 0.10 log units above the measured one; measured number inside the range.
By their numbers in this assay, from the lowest: compounds 1, 3 and 4 (each within the scatter of the next). At a limit, above all of these: compound 2.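

In this assay, cyclohexyl in place of cyclopentyl gives a number 0.20 log units higher from compound 3 to compound 4 (within the scatter), so this change of ring size on the nitrogen cannot be told apart from repeat measurement. Cyclohexyl in place of 1-(4-chlorophenyl)ethyl still gives a number at least 0.50 log units lower from compound 2 to compound 4 (beyond the scatter), so the larger non-aromatic ring keeps the clear drop first seen with cyclopentyl. Compound 2 gives only a limit, and because of this the step has no exact size: the limit of > 4.3 in this assay, at which 1 of the 4 values shown sits.

Going by these compounds, whether a smaller ring such as cyclobutyl, or a cyclohexyl carrying a hydroxyl or an amine, would move the number beyond the scatter stays open.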